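Two chlorines enter the phenyl arm of compound 2

The source may report more compounds than this note shows. Statements on the series, on what has been measured and on what is new or still open speak of the compounds shown alone.

Compound 2 `COc1cccc(COc2ccc3cc(C(=O)/C=C/c4ccccc4)c(=O)oc3c2)c1` is known only by a limit. In a functional assay on K562 cells (Homo sapiens) for cytotoxicity, read by MTT assay, with a stated time of 72 h (on this read-out lower numbers stand for stronger inhibition and higher numbers for weaker inhibition), compound 2 gives > 100000 nM, which is a limit of the assay rather than a number. Compound 1 `COc1ccc(/C=C/C(=O)c2cc3ccc(OCc4cccc(OC)c4)cc3oc2=O)cc1` is likewise known only by a limit. In this assay compound 1 gives > 100000 nM, again a limit. The step that the two limits leave unreadable from compound 1 to compound 2, hydrogen in place of methoxy on an aromatic carbon, stays unreadable since (the limit of > 100000 nM in this assay, at which 2 of the 2 values shown sit). Compound 3 `COc1cccc(COc2ccc3cc(C(=O)/C=C/c4c(Cl)cccc4Cl)c(=O)oc3c2)c1` differs from compound 2 by 2,6-dichlorophenyl in place of phenyl on a double-bonded chain carbon bound to a double-bonded chain carbon. Going by the values given here, no measured step bears on this change; the single step available gives neither size nor direction. Compound 3 is therefore expected to remain at the same limit, the estimated step of a number no higher from compound 2 to compound 3 (the limit leaves the size open) meaning no change beyond the scatter. For compound 3 the estimate is 100000 nM, between 30000 nM and 300000 nM.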

Compound 3, half-maximal inhibitory concentration: 15600 nM
For compound 3 the middle estimate is 6.4-fold (0.81 log units) above the measured one, outside the stated range (below it).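

Going by these compounds alone, replacing the phenyl on the double-bonded chain carbon with 2,6-dichlorophenyl gives the first step in this assay with a readable direction, an at least 6.4-fold lower number from compound 2 to compound 3 (0.80 log units; beyond the scatter), and replacing 4-methoxyphenyl with the same group gives an at least 6.4-fold lower number from compound 1 to compound 3 (0.80 log units; beyond the scatter). This shows that the aryl group at this place can move the read-out, which the pair of compound 1 and compound 2 could not show, as the step between them still cannot be read. Both new steps start from a limit, so they give only a minimum size, and their full size stays open: the limit of > 100000 nM in this assay, at which 2 of the 3 values shown sit.

The compounds shown leave open whether both chlorines are needed, or whether a single chlorine would give a similar number. They also leave open how an amine or a carboxylic acid on this phenyl arm would read in this assay.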